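Removing a methyl from a three-carbon linker

The source may report more compounds than this note shows. Statements on the series, on what has been measured and on what is new or still open speak of the compounds shown alone.

Measured so far:
compound 1 `CC1=C(C(C)CC(=O)OCCCOc2no[n+]([O-])c2S(=O)(=O)c2ccccc2)C(=O)c2c(O)cccc2C1=O`, 92.7%
compound 2 `CC1=C(CCC(=O)OCC(C)COc2no[n+]([O-])c2S(=O)(=O)c2ccccc2)C(=O)c2c(O)cccc2C1=O`, 73.4%

In a functional assay on HepG2 cells (Homo sapiens) for inhibition, read by MTT assay, with a stated time of 72 h, tested at 10 uM (on this read-out higher numbers stand for more inhibition of growth at the one concentration tested and lower numbers for less inhibition of growth), compound 1 gives 92.7%, and compound 2 gives 73.4%, the lower of the two numbers, a gap beyond the usual scatter. Compound 3 `CC1=C(CCC(=O)OCCCOc2no[n+]([O-])c2S(=O)(=O)c2ccccc2)C(=O)c2c(O)cccc2C1=O` has not been measured. It differs from compound 2 by hydrogen in place of methyl on a saturated chain carbon bound to two saturated chain carbons. Among the measured compounds shown here, no single step between measured compounds shows what such a change does, so only a small step is expected here, in this assay upward, perhaps not beyond the scatter. The expected step of a number 6.6 percentage points higher from compound 2 to compound 3 (within the scatter) rests on this. Compound 3 is estimated at 80%, in a range from 65% to 93%.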

Compound 3, percent growth inhibition at one concentration: 95.1%
Estimate against measurement, compound 3: 15.1 percentage points below, and the stated range ends below it.
By their numbers in this assay, from the lowest: compound 2; then compounds 1 and 3 (each within the scatter of the next).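

In this assay, hydrogen in place of methyl on a saturated chain carbon bound to two saturated chain carbons gives a number 21.7 percentage points higher from compound 2 to compound 3 (beyond the scatter) and shows that this one methyl matters. The same change on a saturated chain carbon bound to a double-bonded ring carbon and a saturated chain carbon gives a number 2.4 percentage points higher from compound 1 to compound 3 (within the scatter) and shows that the outcome differs with the place of the methyl.

As far as these compounds go, whether an ethyl group or a hydroxyl at either place would behave like methyl remains open. Nothing measured here explains why the two places differ.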